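This account rests on a few compounds, and the source may have more. Where it says the series, first, only, none or still open, it means among the compounds named here.

Measured so far, in the same assay:
Compound 1 `Cc1ccnc(/C(N)=N/NC(=S)N2CCSCC2)c1`: 84.9%
Compound 2 `N/C(=N\NC(=S)N1CCSCC1)c1ccccn1`: 86%

Both numbers come from a functional assay on A-375 cells (Homo sapiens) for cytotoxicity, read by MTT assay, with a stated time of 72 h, tested at 30 uM; a lower number here means less inhibition of growth, a higher number more inhibition of growth at the concentration tested. Compound 2 gives 86% and compound 1 gives 84.9%; the two lie within the scatter of each other, so neither stands apart from the other, and both show strong inhibition of growth at the concentration tested. Among the compounds with values here, the only measured step, a number 1.1 percentage points higher from compound 1 to compound 2 (within the scatter), concerns a hydrogen in place of a methyl on an aromatic carbon.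

Compound 3 `N/C(=N\NC(=S)N1CCCC1)c1ccccn1` is not yet measured. It differs from compound 2 in a different part of the shared core: pyrrolidin-1-yl in place of thiomorpholin-4-yl on a thiocarbonyl carbon. Within the data shown here, no measured step touches the group on the thiocarbonyl carbon, so the step from compound 1 to compound 2 gives no guide here. With nothing to point either way, and with both measured compounds already sitting high in this assay, no step beyond the scatter is expected, and the estimated step is a number 6 percentage points lower from compound 2 to compound 3 (within the scatter). Compound 3 is expected to give 80%, with a range from 60% to 92%.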

Compound 3, percent growth inhibition at one concentration: 86%
Compound 3: middle estimate off by 6 percentage points, on the low side; the measured number falls inside the stated range.
By their numbers in this assay, from the lowest: compounds 1, 2 and 3 (each within the scatter of the next).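

In this assay, within the data shown here, the first measured change to the group on the thiocarbonyl carbon gives no change at the digits printed from compound 2 to compound 3 (within the scatter) and so stays within the scatter. Going from thiomorpholin-4-yl to pyrrolidin-1-yl removes the ring sulfur, replaces a six-membered ring with a five-membered one and lowers the hydrogen-bond acceptor count of the group, yet strong inhibition of growth remains at the concentration tested; for this pair, then, neither the sulfur nor the larger ring is required for that result. No independent measurement is available to explain why these two groups give matching numbers.

A single high reading at one concentration may hide real differences in potency between compounds, so this match does not show that compound 2 and compound 3 are equally potent. Going by these compounds, it also remains open whether this position would tolerate other groups on the thiocarbonyl carbon, such as morpholin-4-yl, piperidin-1-yl, an open-chain dimethylamino group or a ring bearing a carboxylic acid.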